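Solubility notes: methyl on the fluorophenyl ring

The source may report more compounds than this note shows. Statements on the series, on what has been measured and on what is new or still open speak of the compounds shown alone.

Compound 1 `Cc1cc(NCc2ccccn2)n2nc(C)c(-c3ccc(F)cc3)c2n1`: in a physicochemical assay for solubility, read by HPLC, using the shake flask method, measured as kinetic solubility, with a stated time of 2 h, at pH 7.4 (on this read-out lower numbers stand for lower solubility and higher numbers for higher solubility), compound 1 gives < 5000 nM, a limit.
Compound 2 `Cc1cc(NCc2ccccn2)n2ncc(-c3ccc(F)cc3)c2n1`: in this assay compound 2 gives < 5000 nM, a limit.
Compound 3 `Cc1cc(NCc2ccc3ccccc3n2)n2nc(C)c(-c3ccccc3)c2n1`: in this assay compound 3 gives < 5000 nM, a limit.

Compound 2 stands at the limit of this assay, as do its two neighbours; see (the limit of < 5000 nM in this assay, at which 3 of the 3 values shown sit). For the measured compounds named here, the one single-point step measured, a step that the two limits leave unreadable from compound 1 to compound 2, cannot be sized. Compound 4 `Cc1cc(NCc2ccccn2)n2ncc(-c3ccc(F)cc3C)c2n1` differs from compound 2 by methyl in place of hydrogen on an aromatic carbon. Going by the values given here, no measured step bears on this change, and every value is a limit. The step that the limit leaves unreadable from compound 2 to compound 4 is therefore expected to stay within the scatter, with a limit again the most likely report. Compound 4 is estimated at 2000 nM, between 300 nM and 6000 nM.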

Compound 4, solubility: 42300 nM
Compound 4: middle estimate off by 21-fold (1.33 log units), on the low side, outside the stated range (above it).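

On the 4-fluorophenyl ring, the change to 4-fluoro-2-methylphenyl, ortho to a large group, reads in this assay as an at least 8.4-fold higher number from compound 2 to compound 4 (0.92 log units; beyond the scatter). For the compounds shown here, this is the first readable step, and its size is a floor, not an exact figure. Compound 4 is the only compound shown with a value that is not a limit: the limit of < 5000 nM in this assay, at which 3 of the 4 values shown sit.

Open, from the compounds shown here alone, is whether an ethyl group, a methoxy group or an amine at this same place would read the same way. Also open, going by these compounds, is whether the added methyl gives a comparable step on compound 1.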